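This account rests on a few compounds, and the source may have more. Where it says the series, first, only, none or still open, it means among the compounds named here.

Three compounds were run in a functional assay on MCF7 cells (Homo sapiens) for antiproliferative activity, read by MTT assay, with a stated time of 24 h, tested at 0.001 ug/mL (a higher number here means a weaker effect of the compound at the concentration tested, a lower number a stronger effect), before compound 4 came up. Compound 1 `O=Cc1cn(-c2ccccc2)nc1-c1cccc([N+](=O)[O-])c1` gives 89% in this assay, and compound 2 `O=Cc1cn(-c2ccccc2)nc1-c1ccc(Cl)cc1` gives 98%. Compound 3 `COc1cc(/C=C/C(=O)C(=Cc2cn(-c3ccccc3)nc2-c2ccccc2O)C(=O)/C=C/c2ccc(O)c(OC)c2)ccc1O` gives 97% in this assay, the second highest of the three numbers; its nearest neighbour is compound 2, whose number lies within the scatter of it, and its furthest is compound 1, whose number also lies within the scatter, so the three values cannot be told apart.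

Compound 4 `COc1cc(/C=C/C(=O)C(=Cc2cn(-c3ccccc3)nc2-c2ccc(Cl)cc2)C(=O)/C=C/c2ccc(O)c(OC)c2)ccc1O` carries the same core as compound 3 and differs from it in one place: 4-chlorophenyl in place of 2-hydroxyphenyl on an aromatic carbon. For the measured compounds named here, no step between two measured compounds speaks to this exchange on its own, and the three numbers seen so far sit close together at this concentration. Compound 4 is therefore expected to show a step of a number 1 percentage points lower from compound 3 to compound 4 (within the scatter) that stays within the scatter, in no particular direction. The estimate for compound 4 in this assay is 96%, with a range from 87% to 103%.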

Compound 4, a percentage reported as activity, at one concentration (the size of the read-out at that concentration, not a potency): 81%
Compound 4: middle estimate off by 15 percentage points, on the high side; measured number below the stated range.
By their numbers in this assay, from the lowest: compounds 4, 1, 3 and 2 (each within the scatter of the next, the first and the last beyond it).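

In this assay, the aromatic carbon next to the ring nitrogen proves responsive to the group it carries: 4-chlorophenyl in place of 2-hydroxyphenyl gives a number 16 percentage points lower from compound 3 to compound 4 (beyond the scatter), and the lower number means a stronger effect at the concentration tested. For the compounds shown here, the earlier compounds offered no step between compounds differing in one place, and their numbers could not be told apart, so this is the first readable sign that a change at this position can shift the read-out. Nothing shown here bears on what lies behind this step.

The exchange changes both the substituent and where it sits on the phenyl ring, and the compounds shown do not separate these two changes. Going by these compounds, it also remains open how a phenyl ring bearing an amine or a carboxylic acid would read at this position in this assay.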